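Nitrophenyl swap from compound 3 to compound 4

The source may report more compounds than this note shows. Statements on the series, on what has been measured and on what is new or still open speak of the compounds shown alone.

Values measured so far in an ADME assay on HPLF cells (Homo sapiens) for cytotoxicity, with a stated time of 24 h (a lower number here means that less compound is tolerated, a higher number that more compound is tolerated), for this series:
- compound 1 `COc1cc(/C=C2\CCC/C(=C\c3ccccc3[N+](=O)[O-])C2=O)cc(OC)c1OC` gives 79000 nM as a number
- compound 2 `O=C1/C(=C/c2ccc(F)cc2)CCC/C1=C\c1cccc([N+](=O)[O-])c1` gives 36000 nM as a number
- compound 3 `COc1cc(/C=C2\CCC/C(=C\c3cccc([N+](=O)[O-])c3)C2=O)cc(OC)c1OC` gives > 400000 nM as a limit, not a number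

Compound 3 stands at the limit of > 400000 nM in this assay, at which 1 of the 3 values shown sits, and has no exact place on the scale. Next comes compound 4 `COc1cc(/C=C2\CCC/C(=C\c3ccc([N+](=O)[O-])cc3)C2=O)cc(OC)c1OC` through 4-nitrophenyl in place of 3-nitrophenyl on a double-bonded chain carbon bound to a double-bonded ring carbon with 4-nitrophenyl in place of 3-nitrophenyl on a double-bonded chain carbon bound to a double-bonded ring carbon. One measured change at the same place bears on this, namely an at least 5.0-fold higher number from compound 1 to compound 3 (0.70 log units; beyond the scatter) with 3-nitrophenyl in place of 2-nitrophenyl. That step lies beyond the scatter but does not fix the direction of the next swap. With only a limit for compound 3, a number for compound 4 could only lie lower, and a further limit remains possible. A modest step down is therefore expected in this assay and the estimated change is an at least 2.2-fold lower number from compound 3 to compound 4 (0.34 log units; beyond the scatter) in that direction. Compound 4 is expected at 180000 nM with an estimated range from 50000 nM to 400000 nM.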

Compound 4, half-maximal cytotoxic concentration: 378000 nM
For compound 4 the middle estimate is 2.1-fold (0.32 log units) below the measured one, within the range that was stated.
By their numbers in this assay, from the lowest: compound 2; then compound 1; then compound 4. At a limit, above all of these: compound 3.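

In this assay, swapping 2-nitrophenyl for 4-nitrophenyl gives a 4.8-fold higher number from compound 1 to compound 4 (0.68 log units; beyond the scatter), so the rise seen with 3-nitrophenyl at this place is not unique to that group. Compound 3 holds a limit, not a number: the limit of > 400000 nM in this assay, at which 1 of the 4 values shown sits. The step of an at least 1.0-fold lower number from compound 3 to compound 4 (0.02 log units; that floor lies within the scatter) sets no order between 3-nitrophenyl and 4-nitrophenyl, and only 2-nitrophenyl stands apart among the three in this shared core.

Where compound 3 would fall as an exact number stays open, and with it any ranking of 3-nitrophenyl against 4-nitrophenyl. Also open, on these data alone, is whether an aminophenyl or a carboxyphenyl group at this place would keep the number as high as the two later nitrophenyl isomers do.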